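Swapping the pyrimidine substituents: what to expect for compound 4

The compounds below may be only part of what the source reports. "The series", "measured", "known", "first", "only" and "open" are said of these compounds alone.

Measured compounds:
compound 1 `Cc1cc(C(F)(F)F)cc(NC[C@@H]2CC3(CC3)CN2C(=O)c2nc(C)sc2-c2ccccc2)n1` gives 8.6
compound 2 `Cc1ccnc(NC[C@@H]2CC3(CC3)CN2C(=O)c2nc(C)sc2-c2ccccc2)n1` gives 7
compound 3 `Cc1nc(C(=O)N2CC3(CC3)C[C@H]2CNc2ncc(Cl)cn2)c(-c2ccccc2)s1` gives 6.8

All three values come from a functional assay on HEK293 cells for antagonist activity at Orexin receptor type 2 (Homo sapiens), read by FLIPR and calcium flux; on this read-out higher numbers stand for higher potency (the scale is a negative logarithm) and lower numbers for lower potency. Compound 3 stands lowest of the three; compound 2 lies closest, with a number 0.20 log units lower from compound 2 to compound 3 (within the scatter), while compound 1 is furthest away, with a number 1.80 log units lower from compound 1 to compound 3 (beyond the scatter). The only difference among these compounds is the aromatic group on the amine nitrogen.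

Compound 4 `Cc1cc(C)nc(NC[C@@H]2CC3(CC3)CN2C(=O)c2nc(C)sc2-c2ccccc2)n1` has not been measured. It differs from compound 3 by 4,6-dimethylpyrimidin-2-yl in place of 5-chloropyrimidin-2-yl on an amine nitrogen. The closest measured step is a number 0.20 log units lower from compound 2 to compound 3 (within the scatter), which shows that exchanging a methyl for a chlorine on the pyrimidine changed little. Compound 4 resembles compound 2 with one more methyl, and the large gain seen in a number 1.60 log units lower from compound 1 to compound 2 (beyond the scatter) belongs to a different ring type, so it gives no direct guide. Compound 4 is therefore expected to sit near compound 2, giving an estimated a number 0.50 log units higher from compound 3 to compound 4 (beyond the scatter) in this assay. The estimate for compound 4 is 7.3, with a range from 6.7 to 7.9.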

Compound 4, negative logarithm of the antagonist equilibrium constant: 8.6
Compound 4: middle estimate off by 1.30 log units, on the low side, outside the stated range (above it).
By their numbers in this assay, from the lowest: compounds 3 and 2 (each within the scatter of the next); then compounds 1 and 4 (each within the scatter of the next).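

In this assay, methyl in place of hydrogen on an aromatic carbon of the pyrimidine gives a number 1.60 log units higher from compound 2 to compound 4 (beyond the scatter), so one small addition to this ring can matter greatly, even though compound 2 and compound 3 had looked alike. The change from 5-chloropyrimidin-2-yl to 4,6-dimethylpyrimidin-2-yl likewise gives a number 1.80 log units higher from compound 3 to compound 4 (beyond the scatter). A pyrimidine can also match the pyridine ring of compound 1: 4,6-dimethylpyrimidin-2-yl in place of 6-methyl-4-(trifluoromethyl)pyridin-2-yl gives no change at the digits printed from compound 1 to compound 4 (within the scatter), so in this pair the high number does not depend on the ring type.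

Nothing shown here explains why the added methyl has so large an effect. Going by these compounds, it also remains open whether an ethyl, a methoxy or an amine in place of one methyl of compound 4 would keep this number.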